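The source may report more compounds than this note shows. Statements on the series, on what has been measured and on what is new or still open speak of the compounds shown alone.

Three compounds of the series have numbers in an assay on HEK293 cells for inhibition of Toll-like receptor 8 (Homo sapiens), with a stated time of 16 h; a lower number here means a stronger inhibitor, a higher number a weaker inhibitor. Compound 1 `O=C(Nc1ccc(Oc2cc(C(F)(F)F)cc(C(F)(F)F)c2)cc1)c1sccc1Cl` gives 3200 nM, compound 2 `O=C(Nc1ccc(Oc2cc(C(F)(F)F)cc(C(F)(F)F)c2)cc1O)c1c(F)cccc1I` gives 2630 nM, and compound 3 `O=C(Nc1ccc(Oc2cccc(C(F)(F)F)c2)cc1)c1c(F)cccc1Cl` gives 2410 nM. Compound 3 carries the lowest of the three numbers, but its gaps to compound 2 and to compound 1 both lie within the scatter, so the three stand together rather than in an order. Within the data shown here, no pair among them differs in a single place, so no step between measured compounds can be read off.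

Compound 4 `O=C(Nc1ccc(Oc2cc(I)cc(C(F)(F)F)c2)cc1)c1c(F)cccc1Cl` differs from compound 3 by iodo in place of hydrogen on an aromatic carbon. Among the measured compounds shown here, no measured pair shows what an added iodo does on this ring; compound 1 and compound 2 carry a second trifluoromethyl there, but each also differs from compound 3 elsewhere. The step of a 1.0-fold higher number from compound 3 to compound 4 (0.02 log units; within the scatter) is expected to stay within the scatter, with no direction claimed. The estimated value for compound 4 in this assay is 2500 nM, with a range from 1000 nM to 6500 nM.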

Compound 4, half-maximal inhibitory concentration: 5000 nM
Compound 4: middle estimate off by 2.0-fold (0.30 log units), on the low side, within the range that was stated.
By their numbers in this assay, from the lowest: compounds 3, 2, 1 and 4 (each within the scatter of the next, the first and the last beyond it).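

In this assay, the position meta to the trifluoromethyl group now has its first direct reading: iodo in place of hydrogen gives a 2.1-fold higher number from compound 3 to compound 4 (0.32 log units; beyond the scatter), so this aromatic carbon is not indifferent to substitution, though the step is modest. Among these compounds, compound 1 and compound 2 also carry a group at this place, a second trifluoromethyl, but each differs from compound 3 elsewhere, so this one pair remains the only clean reading of the position. Nothing available gives a reason for the step.

As far as these compounds go, whether the step is particular to iodo stays open, since a chloro, methoxy or amine at the same carbon would be needed to tell. A single pair also leaves open whether iodo has the same effect on the shared core when the other parts of the molecule differ, as they do in compound 1 and compound 2.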